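This account rests on a few compounds, and the source may have more. Where it says the series, first, only, none or still open, it means among the compounds named here.

Among the measured compounds shown here, compound 2 `Oc1ccc(CNc2cc(C(F)(F)F)cc3[nH]ncc23)cc1` holds the highest of the three numbers measured so far in an assay for inhibition of Indoleamine 2,3-dioxygenase 1 (Homo sapiens), with stated times of 10 min and 60 min, tested at 100 uM; a higher number here means a stronger effect of the compound at the concentration tested, a lower number a weaker effect: compound 2 gives 81%. Compound 1 `Nc1cccc(CNc2cc(C(F)(F)F)cc3[nH]ncc23)c1` is the nearest to it; in this assay compound 1 gives 55%. For the measured compounds named here, the step of a number 26 percentage points higher from compound 1 to compound 2 (beyond the scatter) is the only one-place step among the measured compounds. Compound 3 `NCCn1ncc2c(NCc3ccccc3[N+](=O)[O-])cc(C(F)(F)F)cc21` lies furthest away; in this assay compound 3 gives 30%. Compound 3 differs from compound 2 in more than one place, so its value marks only a gap, not a single step.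

The unmeasured compound 4 `O=[N+]([O-])c1ccc(CNc2cc(C(F)(F)F)cc3[nH]ncc23)cc1` differs from compound 2 in one place: nitro in place of hydroxy on an aromatic carbon. Going by the values given here, no measured step swaps a hydroxy for a nitro. The step from compound 1 to compound 2 shows that exchanging the group on this ring can move the number by a modest amount beyond the scatter, and compound 3, which also carries a nitro group but differs in more than one place, sits far lower. A modest fall is therefore expected, and the step of a number 26 percentage points lower from compound 2 to compound 4 (beyond the scatter) is the estimate. Compound 4 is expected to give 55%, within 25% to 85%.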

Compound 4, a percentage reported as inhibition, at one concentration (the size of the read-out at that concentration, not a potency): 61%
For compound 4 the middle estimate is 6 percentage points below the measured one; the measured number falls inside the stated range.
By their numbers in this assay, from the lowest: compound 3; then compounds 1 and 4 (each within the scatter of the next); then compound 2.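

In this assay the change on this aromatic carbon, para to a large group, gives a number 20 percentage points lower from compound 2 to compound 4 (beyond the scatter) with the rest of the molecule unchanged. The fall is modest and compound 4 still gives 61%, so hydroxy, with its 1 hydrogen-bond donor, is not essential for a sizeable effect here: nitro, with 0 hydrogen-bond donors, also gives one. The swap alters heavy atoms, donors and acceptors all at once, and no measurement at hand accounts for the fall.

Still open, on these data alone, is how a methoxy group or a carboxylic acid on this same aromatic carbon would compare with hydroxy and nitro in this assay. As far as these compounds go, these numbers are also read-outs at one concentration, so the potencies of compound 2 and compound 4 remain unknown.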